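The source may report more compounds than this note shows. Statements on the series, on what has been measured and on what is new or still open speak of the compounds shown alone.

Compound 1 `CCCOc1ccc(CN(Cc2ccc(C(C)(C)C)cc2)Cc2cc3cc(C)ccc3[nH]c2=O)cc1` in a toxicity assay on MDCK cells (Canis lupus familiaris) for cytotoxicity, read by crystal violet staining, with a stated time of 48 h (on this read-out lower numbers stand for higher toxicity in this test and higher numbers for lower toxicity in this test), gives > 5000 nM, which is a limit of the assay. Compound 2 `CCCCOc1ccc(CN(Cc2ccc(C(C)(C)C)cc2)Cc2cc3cc(C)ccc3[nH]c2=O)cc1` gives > 5000 nM, also a limit. Compound 3 `Cc1ccc2[nH]c(=O)c(CN(Cc3ccc(OC(F)F)cc3)Cc3ccc(C(C)(C)C)cc3)cc2c1` gives > 5000 nM, again a limit.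

Compound 3 therefore stands at the same limit as the other two; none of the three values is a number. The steps among them carry no readable size: a step that the two limits leave unreadable from compound 1 to compound 2, a step that the two limits leave unreadable from compound 1 to compound 3 and a step that the two limits leave unreadable from compound 2 to compound 3 all remain hidden behind the limits. The one firm observation is the limit of > 5000 nM in this assay, at which 3 of the 3 values shown sit.

Compound 4 `Cc1ccc2[nH]c(=O)c(CN(Cc3ccc(SC(F)(F)F)cc3)Cc3ccc(C(C)(C)C)cc3)cc2c1` differs from compound 3 in a single place: (trifluoromethyl)sulfanyl in place of difluoromethoxy on an aromatic carbon. Going by the values given here, none of the measured steps touches a (trifluoromethyl)sulfanyl group, so the change from compound 3 to compound 4 has no direct precedent here. What can be said is that the groups already varied on that oxygen of the aromatic ring, propyl, butyl and difluoromethyl, all left the value at the limit, and the nearest measured step, a step that the two limits leave unreadable from compound 2 to compound 3, is unreadable. On that basis compound 4 is expected to sit at the limit as well, with a step that the limit leaves unreadable from compound 3 to compound 4 as the expected step. The estimate for compound 4 is 8000 nM, within 4000 nM to 20000 nM, and a limit rather than a number is the likely report.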

Compound 4, half-maximal cytotoxic concentration: > 5000 nM
Compound 4 was reported as a limit; the forecaster's own chance of this, stated with the estimate: 85%; the middle value does not contradict the limit.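

No new step can be read: compound 4, like compound 1, compound 2 and compound 3, is reported only as a limit in this assay, so its steps from all three cannot be read. All four share one result: the limit of > 5000 nM in this assay, at which 4 of the 4 values shown sit.

The compounds shown leave open each compound's actual half-maximal cytotoxic concentration, and therefore whether any of these group changes alters it.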